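This account rests on a few compounds, and the source may have more. Where it says the series, first, only, none or still open, it means among the compounds named here.

Measured so far:

Compound 1 `Nc1nc2c(c(-c3ccco3)cn2[C@@H]2O[C@H](CO)[C@@H](O)[C@H]2O)c(=O)[nH]1` — a limit, > 100000 nM
Compound 2 `COc1nc(N)nc2c1c(-c1ccoc1)cn2[C@@H]1O[C@H](CO)[C@@H](O)[C@H]1O` — a limit, > 100000 nM
Compound 3 `Nc1nc2c(c(-c3ccoc3)cn2[C@@H]2O[C@H](CO)[C@@H](O)[C@H]2O)c(=O)[nH]1` — 86100 nM

All three were tested in an ADME assay on MRC5 cells (Homo sapiens), read by MTT assay, with a stated time of 72 h; on this read-out lower numbers stand for stronger inhibition and higher numbers for weaker inhibition. Among the measured compounds shown here, compound 3 is the only one to give a number here, at 86100 nM. For compound 1 the assay reports only a limit, > 100000 nM. For compound 2 it likewise reports only a limit, > 100000 nM.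

Compound 3 and compound 1 differ in one place: furan-2-yl in place of furan-3-yl on an aromatic carbon. The step is an at least 1.1-fold higher number from compound 3 to compound 1 (0.06 log units; that floor lies within the scatter), and its floor sits within the usual scatter, so the two cannot be told apart. This fits because the limit of > 100000 nM in this assay, at which 2 of the 3 values shown sit, shows that most of the values here are limits rather than numbers.

Compound 2 and compound 3 share a related core, but the difference between the two cores is not broken down here. Compound 4 `COc1nc(N)nc2c1c(-c1ccco1)cn2[C@@H]1O[C@H](CO)[C@@H](O)[C@H]1O` has not yet been measured. It differs from compound 2 by the same change: furan-2-yl in place of furan-3-yl on an aromatic carbon. The place of the change is described in the same words for both pairs, so it is the same change.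

Compound 4 is expected to behave like compound 2, whose result in this assay is the limit > 100000 nM. The expected step is a step that the limit leaves unreadable from compound 2 to compound 4, resting on the near-flat step from compound 3 to compound 1, an at least 1.1-fold higher number from compound 3 to compound 1 (0.06 log units; that floor lies within the scatter). The estimate for compound 4 is 150000 nM, between 80000 nM and 400000 nM, most likely again only a limit.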

Compound 4, half-maximal inhibitory concentration: 89700 nM
Estimate against measurement, compound 4: 1.7-fold (0.22 log units) above, within the range that was stated.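

Compound 2 gives only a limit in this assay, > 100000 nM, and not a number. Going by these compounds, putting furan-2-yl in place of furan-3-yl therefore yields only a floor, an at least 1.1-fold lower number from compound 2 to compound 4 (0.04 log units; that floor lies within the scatter), so compound 2 and compound 4 cannot be told apart, and the true size of the step, and even whether there is one, stays unknown. On both cores the swap has so far produced no step that clears the usual scatter, but this does not show that the change is without effect or that it carries over unchanged from one core to the other, and the two steps can be set side by side only with that caution: the same change on two cores in this assay, an at least 1.1-fold higher number (0.06 log units; that floor lies within the scatter) from compound 3 to compound 1 and an at least 1.1-fold lower number (0.04 log units; that floor lies within the scatter) from compound 2 to compound 4; the limit leaves it open whether they differ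

Whether the swap matters on either core stays open, and a firmer answer would need two numbers on each core rather than a number set against a limit, which is hard to come by where so many results sit at the same ceiling: the limit of > 100000 nM in this assay, at which 2 of the 4 values shown sit. The compounds shown also leave open what an amine, a carboxylic acid or a longer chain would give on that same aromatic carbon in place of the furan ring, and whether any such group would bring a result clearly away from that limit.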